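A few compounds are considered here, and "the series" means these few. Any claim that something is new, unique, unknown or untested is made for them only; others in the source may bear on it.

Measured so far:
compound 1 `O=C(/C=C/c1ccc(O)cc1)N1CCCC1`, 3.51%
compound 2 `O=C(/C=C/c1ccc(O)c(O)c1)N1CCCC1`, 83.2%

In a functional assay, with a stated time of 30 min, tested at 1 mM (a lower number here means less inhibition, a higher number more inhibition at the concentration tested (going by the name of the read-out)), compound 1 stands lowest of the two numbers; the nearest measured compound is compound 2, reached by a step that is a number 79.7 percentage points higher from compound 1 to compound 2 (beyond the scatter). The new compound 3 `O=C(/C=C/c1ccc(O)cc1O)N1CCCC1` also differs from compound 1 by one change: hydroxy in place of hydrogen on an aromatic carbon. Among the measured compounds shown here, the only measured step that bears on this change is the one from compound 1 to compound 2, which likewise puts a hydroxy in place of hydrogen on an aromatic carbon, and that step was large. For the measured compounds named here, the entering hydroxy of compound 3, however, sits at a different position of the ring, ortho to a group of 9 heavy atoms and meta to a hydroxy group, so the single measured step is only a loose guide. An increase in this assay from compound 1 to compound 3 is therefore expected, but a smaller one than the measured step, and with wide uncertainty: the estimated step is a number 21.5 percentage points higher from compound 1 to compound 3 (beyond the scatter). Compound 3 is expected to give about 25% in this assay, within a range of 3% to 70%.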

Compound 3, a percentage reported as inhibition, at one concentration (the size of the read-out at that concentration, not a potency): 22.3%
Compound 3: middle estimate off by 2.7 percentage points, on the high side, within the range that was stated.
By their numbers in this assay, from the lowest: compound 1; then compound 3; then compound 2.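

In this assay, putting hydroxy in place of hydrogen on an aromatic carbon, ortho to a group of 9 heavy atoms and meta to a hydroxy group, gives a number 18.8 percentage points higher from compound 1 to compound 3 (beyond the scatter), a modest step that still lies beyond the usual scatter. The same kind of change at a different position of the ring gave a number 79.7 percentage points higher from compound 1 to compound 2 (beyond the scatter), a large step, so among these compounds the size of the gain depends on where the new hydroxy enters and not only on its presence. No measurement shown explains why the two positions differ.

It remains open whether the oxygen of the new hydroxy is what counts at this position, since the compounds shown include no methoxy, fluorine or amine there for comparison. Also open, as far as these compounds go, is whether a larger group at the same place, such as a carboxylic acid or a longer chain ending in a hydroxy, would raise the number in this assay further, leave it unchanged or lower it.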